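Trichlorophenyl extension of an oxy-linked dihydrofolate reductase series

This account rests on a few compounds, and the source may have more. Where it says the series, first, only, none or still open, it means among the compounds named here.

Measured so far:
- compound 1 `NC1=NC2(CCOCC2)N(OCCCOc2ccccc2)C(N)=N1` in an assay on isolated protein for inhibition of Dihydrofolate reductase (Homo sapiens), read by spectrophotometry, using NADPH, with stated times of 5 s and 6 min, tested at 5 uM (a higher number here means a stronger effect of the compound at the concentration tested, a lower number a weaker effect), gives > 90%, a limit of the assay.
- compound 2 `NC1=NC2(CCOCC2)N(OCCCOc2ccc(F)cc2)C(N)=N1` in this assay gives > 90%, a limit.
- compound 3 `NC1=NC2(CCOCC2)N(OCCCOc2ccc(Cl)c(Cl)c2)C(N)=N1` in this assay gives > 90%, a limit.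

Compound 3 stands at the limit, and the two other values shown are limits as well, as the limit of > 90% in this assay, at which 3 of the 3 values shown sit, records. The steps a step that the two limits leave unreadable from compound 1 to compound 2, a step that the two limits leave unreadable from compound 1 to compound 3 and a step that the two limits leave unreadable from compound 2 to compound 3 are all unreadable for that reason, so the measured series gives no size for any change to the aryl group.

Compound 4 `NC1=NC2(CCOCC2)N(OCCCOc2cc(Cl)c(Cl)cc2Cl)C(N)=N1` carries one more chlorine than compound 3: chloro in place of hydrogen on an aromatic carbon. Among the compounds with values here, no measured step bears on this change in a readable way; the three steps above only show that every aryl variant reached the limit. The expected step from compound 3 is therefore a step that the limit leaves unreadable from compound 3 to compound 4, that is, no readable change. Compound 4 is estimated at 95% in this assay, with a range from 85% to 100%, and most likely again reported only as the limit.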

Compound 4, a percentage reported as inhibition, at one concentration (the size of the read-out at that concentration, not a potency): > 90%
Compound 4 gave a limit, no number; the forecaster's own chance of this, stated with the estimate: 85%; the middle value is on the limit's open side.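

No step from compound 1, compound 2 or compound 3 to compound 4 can be read in this assay, because all four compounds sit at the same limit: the limit of > 90% in this assay, at which 4 of the 4 values shown sit.

The compounds shown leave open whether the phenyl, 4-fluorophenyl, 3,4-dichlorophenyl and 2,4,5-trichlorophenyl groups differ in inhibition at all, and by how much.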